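The source may hold more compounds than are shown below. What is called first, only, known or untested is meant among the compounds shown, and "the series" means these compounds.

Compound 1 `COc1ccc(N/N=C2\C(=O)N(Cc3cn(C[C@H]4O[C@@H]5OC(C)(C)O[C@@H]5[C@H]4O)nn3)c3ccccc32)cc1`: 74500 nM
Compound 2 `CC1(C)O[C@H]2O[C@H](Cn3cc(CN4C(=O)/C(=N\Nc5ccc(F)cc5)c5ccccc54)nn3)[C@H](O)[C@H]2O1`: 83800 nM
Compound 3 `CC1(C)O[C@H]2O[C@H](Cn3cc(CN4C(=O)/C(=N\Nc5cccc(Cl)c5)c5ccccc54)nn3)[C@H](O)[C@H]2O1`: 70000 nM

In an ADME assay on Vero cells (Chlorocebus sabaeus) for cytotoxicity, read by fluorescence and resazurin assay, with a stated time of 3 days (on this read-out lower numbers stand for higher toxicity in this test and higher numbers for lower toxicity in this test), compound 1 gives 74500 nM, while compound 2 gives 83800 nM and compound 3 gives 70000 nM. Compound 1 sits in the middle of these three numbers, and its steps of a 1.1-fold higher number from compound 1 to compound 2 (0.05 log units; within the scatter) and a 1.1-fold lower number from compound 1 to compound 3 (0.03 log units; within the scatter) are both within the scatter, as is a 1.2-fold lower number from compound 2 to compound 3 (0.08 log units; within the scatter). Compound 4 `COc1ccc(N/N=C2\C(=O)N(Cc3cn(O[C@@H]4O[C@H](CO)[C@H](O)[C@H](O)[C@H]4O)nn3)c3ccccc32)cc1` differs from compound 1 by a group of 12 heavy atoms (6 carbon, 6 oxygen; one six-membered non-aromatic ring with 1 hetero atom) in place of a group of 12 heavy atoms (8 carbon, 4 oxygen; one five-membered non-aromatic ring with 1 hetero atom, one five-membered non-aromatic ring with 2 hetero atoms), on an aromatic nitrogen. Every measured step changes only the substituted phenyl on the amine nitrogen, so none bears on this change at the aromatic nitrogen, and the data give no guidance there. With all three measured compounds so close together, no step beyond the scatter is expected in this assay. Compound 4 is expected to give 78000 nM, with a range from 40000 nM to 160000 nM. This expectation means the step of a 1.0-fold higher number from compound 1 to compound 4 (0.02 log units; within the scatter).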

Compound 4, half-maximal cytotoxic concentration: 76200 nM
The estimate for compound 4 lay 1.0-fold (0.01 log units) above the measured number; measured number inside the range.
By their numbers in this assay, from the lowest: compounds 3, 1, 4 and 2 (each within the scatter of the next).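

Within the data shown here, the earlier compounds changed only the substituted phenyl on the amine nitrogen, whereas compound 4 is the first to change the group on the aromatic nitrogen of the five-membered aromatic ring with 3 nitrogen. Placing (3,4,5-trihydroxy-6-(hydroxymethyl)oxan-2-yl)oxy there gives a 1.0-fold higher number from compound 1 to compound 4 (0.01 log units; within the scatter) in this assay, so exchanging these two quite different groups produces no readable shift in this test. Nothing available explains this result. From the compounds shown here alone, it remains open whether a simple amine or a carboxylic acid at this position would read the same. Going by these compounds, it also remains open whether this group would do so alongside the 4-fluorophenyl or 3-chlorophenyl.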